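The compounds below may be only part of what the source reports. "The series", "measured", "known", "first", "only" and "open" are said of these compounds alone.

In a functional assay on A549 cells (Homo sapiens) for cytotoxicity, read by MTT assay, with a stated time of 72 h (a lower number here means that less compound is needed, a higher number that more compound is needed for the effect), compound 1 `CCOc1c(-c2occ(C)c2C(=O)O)ccc2c(CC)cccc12` gives > 10 ug/mL, which is a limit of the assay and not a number. Among the compounds with values here, compound 2 `CCOC(=O)c1c(C)coc1-c1ccc2c(CC)cccc2c1OC` gives 3.8 ug/mL, the only actual number so far in this assay. Compound 3 `CCc1cccc2c(OC)c(-c3occ(C)c3C(=O)On3nnc4ccccc43)ccc12` has yet to be measured. It differs from compound 2 as follows: a group of 9 heavy atoms (6 carbon, 3 nitrogen; one five-membered aromatic ring with 3 hetero atoms, one six-membered aromatic ring of carbon only) in place of a group of 2 heavy atoms (2 carbon; no ring), on an oxygen next to a carbonyl group. A group of 9 heavy atoms thus replaces ethyl on an oxygen next to a carbonyl group. Within the data shown here, no measured pair differs in this one place alone, so no shift beyond the scatter is expected, and the estimated step is a 1.1-fold higher number from compound 2 to compound 3 (0.02 log units; within the scatter). For compound 3 the estimated value is 4 ug/mL, with an expected range of 1.5 ug/mL to 10 ug/mL.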

Compound 3, concentration for half-maximal effect: > 10 ug/mL
Compound 3: a limit, no number; the forecaster's own chance of this, stated with the estimate: 15%; middle value at least 2.5-fold (0.39 log units) from the limit.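

Within the data shown here, replacing ethyl with the group of 9 heavy atoms, on an oxygen next to a carbonyl group, gives the first readable step at this place in this assay, with an at least 2.6-fold higher number from compound 2 to compound 3 (0.42 log units; beyond the scatter). This place therefore does not accept every group without a change in the number. The true size of the step cannot be told, since the reading of compound 3 is a limit and not a number: the limit of > 10 ug/mL in this assay, at which 2 of the 3 values shown sit.

As far as these compounds go, whether methyl or a longer chain such as butyl on this oxygen would keep a number like that of compound 2 remains open. So does the effect of an amide nitrogen in place of this oxygen.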